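The compounds below may be only part of what the source reports. "The series", "measured", "known", "first", "only" and "open" are said of these compounds alone.

Measured compounds:
Compound 1 `Cc1ccc(C(=O)Nc2ccc(C#N)cc2)c(O)c1` — in a functional assay on HL-60 cells (Homo sapiens) for cytotoxicity, read by luminescence and CellTiter-Glo, with a stated time of 3 days (a lower number here means a stronger inhibitor, a higher number a weaker inhibitor), compound 1 gives 2420 nM
Compound 2 `O=C(Nc1ccc(Cl)c(C(F)(F)F)c1)c1cc(F)ccc1O` — in this assay compound 2 gives 600 nM

Compound 1 stands highest of these two numbers; compound 2, its nearest neighbour, lies lower by a gap beyond the usual scatter. Compound 3 `N#Cc1ccc(NC(=O)c2ccccc2O)cc1` has not yet been measured in this assay. It differs from compound 1 in a single place: hydrogen in place of methyl on an aromatic carbon. Among the compounds with values here, no measured pair shows this change, so its size is uncertain; a small step is expected, if anything a mild weakening, and possibly none beyond the scatter. Compound 3 is therefore estimated at 3000 nM, with a range of 1200 nM to 8000 nM, which means an expected step of a 1.2-fold higher number from compound 1 to compound 3 (0.09 log units; within the scatter).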

Compound 3, half-maximal inhibitory concentration: 4620 nM
Beside the measured number, compound 3's estimate is 1.5-fold (0.19 log units) below it; low and high end bracket the measured number.
By their numbers in this assay, from the lowest: compound 2; then compounds 1 and 3 (each within the scatter of the next).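

In this assay, hydrogen in place of methyl on this aromatic carbon, meta to a hydroxy group and para to a large group, gives a 1.9-fold higher number from compound 1 to compound 3 (0.28 log units; within the scatter). This first direct reading at the position shows that, on the core of compound 1, the two substituents cannot be told apart in this read-out. No measured evidence accounts for this result. The compounds shown leave open whether an amine, a methoxy group or a carboxylic acid on the same carbon would give a step beyond the scatter.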